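The source may hold more compounds than are shown below. What is called first, only, known or untested is meant among the compounds shown, and "the series" means these compounds.

Measured in a functional assay on CCRF-CEM cells (Homo sapiens) for antiproliferative activity; a higher number here means a weaker inhibitor of growth, a lower number a stronger inhibitor of growth:
- compound 1 `COC(=O)CCCCCCCCCCCCCC/C=C1\CC(CO)(COC(=O)C(C)(C)C)OC1=O`: 0.691 ug/mL
- compound 2 `CC(=O)OCCCCCCCCCCCCCCC/C=C1\CC(CO)(COC(=O)C(C)(C)C)OC1=O`: 7.55 ug/mL

For the measured compounds named here, compound 2, at 7.55 ug/mL, holds the higher of the two numbers in this assay, and compound 1 is its only neighbour. The next structure is compound 3 `CC(=O)NCCCCCCCCCCCCCCC/C=C1\CC(CO)(COC(=O)C(C)(C)C)OC1=O`, and the change is acetamido in place of acetoxy on a saturated chain carbon, ten or more bonds along the chain from a double-bonded chain carbon. Going by the values given here, the one measured step that bears on it is an 11-fold higher number from compound 1 to compound 2 (1.04 log units; beyond the scatter), a large step beyond the scatter, at the same place on the chain. Among the compounds with values here, that step is a different exchange, however, and no measured pair swaps acetoxy for acetamido. It shows that the number can move widely with a change at this place, but it gives no direction for this one. Within the data shown here, no large step is therefore assumed, and the range is kept wide. The expected change is a 1.5-fold lower number from compound 2 to compound 3 (0.18 log units; within the scatter). For compound 3 the estimated value is 5 ug/mL, with an expected range of 1.2 ug/mL to 20 ug/mL.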

Compound 3, concentration for 50% growth inhibition: 1.08 ug/mL
Compound 3: the middle estimate sits 4.6-fold (0.67 log units) above what was measured, and the stated range ends above it.
By their numbers in this assay, from the lowest: compounds 1 and 3 (each within the scatter of the next); then compound 2.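

In this assay, acetamido in place of acetoxy gives a 7.0-fold lower number from compound 2 to compound 3 (0.84 log units; beyond the scatter), so a second exchange at this place on the chain moves the number beyond the scatter, and this one shows a direction for the acetoxy-to-acetamido swap that the earlier step could not give. Acetamidomethyl in place of methoxycarbonyl gives a 1.6-fold higher number from compound 1 to compound 3 (0.19 log units; within the scatter), which lies within the scatter, so compound 1 and compound 3 cannot be ordered and, of the three, only compound 2 stands apart from the others. No supporting data bear on what lies behind this pattern.

Still open, from the compounds shown here alone, is how a free amine or a carboxylic acid at this place would compare with these groups. Also open, going by these compounds, is whether a longer chain or a shorter chain would keep the same ordering among the acetoxy, acetamido and methoxycarbonyl compounds.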